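Trihydroxyphenyl in place of dimethylaminophenyl on the enone carbon

The source may report more compounds than this note shows. Statements on the series, on what has been measured and on what is new or still open speak of the compounds shown alone.

Measured compounds:
compound 1, `CN(C)c1ccc(/C=C(/SCc2ccc(Cl)cc2Cl)C(=O)c2ccc(Cl)cc2)cc1`, 50000 nM
compound 2, `Cc1ccc(CS/C(=C/c2ccc(N(C)C)cc2)C(=O)c2ccc(Cl)cc2)cc1`, > 100000 nM
compound 3, `Cc1ccc(S/C(=C/c2ccc(N(C)C)cc2)C(=O)c2ccc(Cl)cc2)cc1`, > 100000 nM

In a functional assay on DU-145 cells (Homo sapiens) for inhibition, read by trypan blue exclusion, with a stated time of 96 h (a higher number here means a weaker inhibitor of growth, a lower number a stronger inhibitor of growth), compound 1 gives 50000 nM. For compound 2 the assay reports only a limit, > 100000 nM. For compound 3 the result is likewise a limit, > 100000 nM. Compound 2 therefore stands at the limit of > 100000 nM in this assay, at which 2 of the 3 values shown sit. The measured steps of an at least 2.0-fold higher number from compound 1 to compound 2 (0.30 log units; that floor lies within the scatter) and an at least 2.0-fold higher number from compound 1 to compound 3 (0.30 log units; that floor lies within the scatter) concern the group on the sulfur, and the step that the two limits leave unreadable from compound 2 to compound 3 cannot be read. Compound 4 `Cc1ccc(CS/C(=C/c2ccc(O)c(O)c2O)C(=O)c2ccc(Cl)cc2)cc1` differs from compound 2 at another place: 2,3,4-trihydroxyphenyl in place of 4-(dimethylamino)phenyl on a double-bonded chain carbon bound to a double-bonded chain carbon. For the measured compounds named here, none of the measured steps touches that position, so no step size can be taken from them. Compound 4 is expected to give 40000 nM, between 8000 nM and 200000 nM. That estimate means a step of an at least 2.5-fold lower number from compound 2 to compound 4 (0.39 log units; beyond the scatter), with a fair chance that only a limit is again reported.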

Compound 4, concentration for 50% growth inhibition: 50000 nM
The estimate for compound 4 lay 1.3-fold (0.10 log units) below the measured number, within the range that was stated.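

In this assay, 2,3,4-trihydroxyphenyl in place of 4-(dimethylamino)phenyl on a double-bonded chain carbon bound to a double-bonded chain carbon gives an at least 2.0-fold lower number from compound 2 to compound 4 (0.30 log units; that floor lies within the scatter), the only change at this position among the compounds shown. Compound 4 returns a number where compound 2 returns only a limit, so the true size of this step stays unknown: the limit of > 100000 nM in this assay, at which 2 of the 4 values shown sit.

Going by these compounds, whether a single hydroxyl or a methoxy group on this phenyl ring would give a number in this assay remains open. So does the result of pairing 2,3,4-trihydroxyphenyl with 2,4-dichlorobenzyl on the sulfur.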